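The compounds below may be only part of what the source reports. "The series", "measured", "known", "first", "only" and "open" are said of these compounds alone.

In a functional assay on RS4-11 cells (Homo sapiens) for inhibition, read by CCK-8 assay, with a stated time of 48 h, tested at 20 uM (a higher number here means more inhibition of growth at the concentration tested, a lower number less inhibition of growth), three compounds sharing one core have been measured so far. Compound 1 `COc1ccc(S(=O)(=O)Oc2ccccc2/C=C(\C#N)C(=O)Nc2nnc(-c3cccs3)s2)cc1` gives 76%, compound 2 `COc1ccc(S(=O)(=O)Oc2ccccc2/C=C(\C#N)C(=O)Nc2nnc(Cc3ccccc3)s2)cc1` gives 78%, and compound 3 `N#C/C(=C\c1ccccc1OS(=O)(=O)c1ccccc1[N+](=O)[O-])C(=O)Nc1nnc(Cc2ccccc2)s1` gives 71%. The gaps between compound 2 and the other two lie within the usual scatter of such measurements, so compound 2 stands level with both.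

Compound 4 `COc1ccc(S(=O)(=O)Oc2ccccc2/C=C(\C#N)C(=O)Nc2nnc(Cc3cccc(F)c3)s2)cc1` is compound 2 with one small edit, fluoro in place of hydrogen on an aromatic carbon, which turns benzyl into 3-fluorobenzyl. Going by the values given here, no measured pair shows this exact change, so the evidence is indirect. The closest step concerns the same group: benzyl in place of thiophen-2-yl came with a number 2 percentage points higher from compound 1 to compound 2 (within the scatter). At the other end of the molecule, 2-nitrophenyl in place of 4-methoxyphenyl on the sulfonyl sulfur came with a number 7 percentage points lower from compound 2 to compound 3 (within the scatter). Each of these exchanges a whole ring group and still stays within the scatter, whereas the new change swaps only hydrogen for fluoro. A shift beyond the scatter is therefore not expected in this assay, and the estimated outcome is a number 1 percentage points lower from compound 2 to compound 4 (within the scatter). For compound 4 the expected value is 77%, with an estimated range from 66% to 87%.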

Compound 4, percent growth inhibition at one concentration: 74%
Beside the measured number, compound 4's estimate is 3 percentage points above it, and the stated range covers the measured number.
By their numbers in this assay, from the lowest: compounds 3, 4, 1 and 2 (each within the scatter of the next).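

In this assay the benzyl group of compound 2 takes a fluoro on its six-membered aromatic ring, meta to a large group, and the result is a number 4 percentage points lower from compound 2 to compound 4 (within the scatter) for this single-atom change, so one fluorine at this place leaves the growth inhibition level with that of the parent. Replacing the thiophen-2-yl of compound 1 with 3-fluorobenzyl gives a number 2 percentage points lower from compound 1 to compound 4 (within the scatter) as well, which means that thiophen-2-yl, benzyl and 3-fluorobenzyl all stand level on that aromatic carbon in this read-out at one concentration. Nothing measured here gives a reason for this level result or shows what the fluorine does in the cells.

The compounds shown do not tell whether the ring tolerates any change at this place or only one as small as swapping hydrogen for fluoro, and an amine, a carboxylic acid or a methoxy group there would test this. They also leave open whether a longer chain in place of the benzyl link would shift the number beyond the scatter, and whether compounds that stand level at one concentration would still do so across a range of concentrations.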